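A few compounds are considered here, and "the series" means these few. Any claim that something is new, unique, unknown or untested is made for them only; others in the source may bear on it.

Among the compounds with values here, compound 1, `Cn1ncc(Cl)c1-c1cc(C(=O)N[C@@H]2CN[C@H](CCN3CCCCC3)C[C@H]2c2ccc(Cl)c(Cl)c2)oc1Cl`, is one of two compounds measured in a functional assay on LNCaP cells (Homo sapiens) for antiproliferative activity; on this read-out higher numbers stand for weaker inhibition and lower numbers for stronger inhibition. In this assay compound 1 gives 1780 nM, the higher of the two numbers. The other measured compound, compound 2, `CNC(=O)C[C@@H]1C[C@@H](c2ccc(F)c(F)c2)[C@H](NC(=O)c2cc(-c3c(Cl)cnn3C)c(Cl)o2)CN1`, shares the amide-linked core but differs in several places at once; in this assay compound 2 gives 50 nM, a lower number that lies beyond the usual scatter of such measurements. No single-point comparison between measured compounds is available, so the effect of the change to compound 3, `Cn1ncc(Cl)c1-c1cc(C(=O)N[C@@H]2CN[C@H](CCN3CCCC3)C[C@H]2c2ccc(Cl)c(Cl)c2)oc1Cl`, rests on the change alone: pyrrolidin-1-yl in place of piperidin-1-yl on a saturated chain carbon, two bonds along the chain from a saturated ring carbon. Both groups carry one acceptor and no donor and sit on the same saturated chain carbon; the ring simply shrinks by one carbon. For that reason the step of a 1.2-fold lower number from compound 1 to compound 3 (0.07 log units; within the scatter) is expected to be small, with no clear direction beyond the scatter. Compound 3 is estimated at 1500 nM, within a range from 600 nM to 4000 nM.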

Compound 3, half-maximal inhibitory concentration: 1920 nM
Compound 3: middle estimate off by 1.3-fold (0.11 log units), on the low side, and the stated range covers the measured number.
By their numbers in this assay, from the lowest: compound 2; then compounds 1 and 3 (each within the scatter of the next).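

In this assay, within the data shown here, the first direct comparison at this position gives a 1.1-fold higher number from compound 1 to compound 3 (0.03 log units; within the scatter), so pyrrolidin-1-yl and piperidin-1-yl on this saturated chain carbon cannot be told apart on this read-out. On the core of compound 1, a five-membered and a six-membered non-aromatic ring at this place therefore read alike, which shows that this one-carbon difference in ring size does not register here. No measurement at hand offers an explanation for this result.

The compounds shown leave open whether a different group at the end of the chain, such as morpholin-4-yl, dimethylamino or a carboxylic acid, would read differently from these two rings. They also leave open what a shorter or longer chain carrying the same rings would give, and whether this swap would read alike on the core of compound 2.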